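The compounds below may be only part of what the source reports. "The series", "measured", "known", "first", "only" and "open" are said of these compounds alone.

Compound 1 `COc1ccc(-c2cn3ccnc3c(-c3ccc4ncn(C5CCCCC5)c4c3)n2)cc1` gives 53.4% in a functional assay on IGROV-1 cells (Homo sapiens) for inhibition, read by sulforhodamine B assay, with a stated time of 48 h, tested at 10 uM; a lower number here means less inhibition, a higher number more inhibition at the concentration tested (going by the name of the read-out).
Compound 2 `O=Cc1ccc(-c2cn3ccnc3c(-c3ccc4ncn(C5CCCCC5)c4c3)n2)cc1` gives 21.3% in this assay.
Compound 3 `CC(=O)c1ccc(-c2cn3ccnc3c(-c3ccc4ncn(C5CCCCC5)c4c3)n2)cc1` gives 19.1% in this assay.

Among these three numbers compound 3 stands lowest. Its nearest neighbour is compound 2, and the pair sit so close that the step of a number 2.2 percentage points lower from compound 2 to compound 3 (within the scatter) lies within the scatter, so no order can be read between them. The gap to compound 1 is large: a number 34.3 percentage points lower from compound 1 to compound 3 (beyond the scatter), and the parallel step a number 32.1 percentage points lower from compound 1 to compound 2 (beyond the scatter) is of the same kind and size. In both steps the methoxy group gives way to a group carrying a carbonyl, and inhibition drops sharply.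

Compound 4 `Brc1ccc(-c2cn3ccnc3c(-c3ccc4ncn(C5CCCCC5)c4c3)n2)cc1` differs from compound 3 in one place: bromo in place of acetyl on an aromatic carbon. Among the measured compounds shown here, no measured step makes this exact change. What can be drawn on is that removing the carbonyl-bearing groups in reverse of a number 34.3 percentage points lower from compound 1 to compound 3 (beyond the scatter) restores much inhibition, while a number 2.2 percentage points lower from compound 2 to compound 3 (within the scatter) shows that the detail of the carbonyl group matters little. Bromo carries no carbonyl, so the step of a number 20.9 percentage points higher from compound 3 to compound 4 (beyond the scatter) is expected to go upward, though with wide uncertainty since bromo is not methoxy. Compound 4 is therefore estimated at 40%, within 18% to 62%.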

Compound 4, a percentage reported as inhibition, at one concentration (the size of the read-out at that concentration, not a potency): 9.4%
Compound 4: the middle estimate sits 30.6 percentage points above what was measured; measured number below the stated range.
By their numbers in this assay, from the lowest: compounds 4, 3 and 2 (each within the scatter of the next, the first and the last beyond it); then compound 1.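

Removing the carbonyl from this position, para to a large group, does not by itself restore inhibition: in this assay bromo in place of acetyl gives a number 9.7 percentage points lower from compound 3 to compound 4 (within the scatter) and leaves the two compounds indistinguishable. Bromo in place of formyl gives a number 11.9 percentage points lower from compound 2 to compound 4 (beyond the scatter) and bromo in place of methoxy gives a number 44 percentage points lower from compound 1 to compound 4 (beyond the scatter) so among these four groups methoxy alone stands clearly apart, and the presence or absence of a carbonyl does not account for the split. Nothing available explains what sets methoxy apart.

The compounds shown leave open whether this higher inhibition belongs to methoxy alone or extends to relatives on the same carbon, such as an ethoxy chain, a hydroxyl or an amine. They also leave open whether methoxy would keep its effect elsewhere on the same ring.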